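Arpromidine-type guanidines: aryl swap at the chain carbon

A few compounds are considered here, and "the series" means these few. Any claim that something is new, unique, unknown or untested is made for them only; others in the source may bear on it.

Measured compounds:
compound 1 `N=C(NCCCc1c[nH]cn1)NCCC(c1ccccc1)c1ccccn1`: 0.7
compound 2 `N=C(NCCCc1c[nH]cn1)NCCC(c1cccc(F)c1)c1ccccn1`: 0.5
compound 3 `N=C(NCCCc1c[nH]cn1)NCCC(c1cccc(C(F)(F)F)c1)c1ccccn1`: 0.7

In a functional assay on muscle tissue for agonist activity at histamine H2 receptor (Cavia porcellus) (on this read-out higher numbers stand for larger maximal responses and lower numbers for smaller maximal responses), compound 1 and compound 3 stand level at the top of the three numbers, and compound 2 gives the lowest value. The steps on the phenyl ring were modest: a number 0.20 lower from compound 1 to compound 2 (beyond the scatter), no change at the digits printed from compound 1 to compound 3 (within the scatter), a number 0.20 higher from compound 2 to compound 3 (beyond the scatter).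

Compound 4 `N=C(NCCCc1c[nH]cn1)NCCC(c1ccccc1)c1ccc(Cl)c(Cl)c1` differs from compound 1 in another place, (3,4-dichlorophenyl in place of pyridin-2-yl on a saturated chain carbon bound to an aromatic carbon and a saturated chain carbon). Among the compounds with values here, no measured step concerns this position; the three measured steps only show that changes on an aromatic ring of this series move this assay by modest amounts in either direction. Given the lack of a direct precedent, a modest downward step a number 0.20 lower from compound 1 to compound 4 (beyond the scatter) is expected. Compound 4 is estimated at 0.5, within 0.2 to 0.8.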

Compound 4, intrinsic activity: the largest response reached, as a fraction of the reference agonist's: 0.6
Estimate against measurement, compound 4: 0.10 below; measured number inside the range.
By their numbers in this assay, from the lowest: compounds 2, 4, 1 and 3 (each within the scatter of the next, the first and the last beyond it).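

In this assay, 3,4-dichlorophenyl in place of pyridin-2-yl on the saturated chain carbon gives a number 0.10 lower from compound 1 to compound 4 (within the scatter). At this position, then, a ring of carbon only, with no hydrogen-bond acceptor, holds the maximal response within the scatter of compound 1, so the ring nitrogen of pyridin-2-yl is not required on this read-out in this pair. Nothing available explains this result.

The swap removes the ring nitrogen and adds both chlorines at once, so their separate contributions stay unresolved. Open too, going by these compounds, is how a single chloro on that ring, or a carboxylic acid at the same chain carbon, would read in this assay.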